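The source may hold more compounds than are shown below. What is called first, only, known or untested is meant among the compounds shown, and "the series" means these compounds.

Compound 1 `Cc1ccc(NC(=O)c2cccc(/C=C3\CC(=O)N(c4ccccc4)C3=O)c2)cc1` and compound 2 `Cc1ccc(N2C(=O)C/C(=C\c3cccc(C(=O)Nc4cccc(F)c4)c3)C2=O)cc1` are built on the same core, with the two aryl groups arranged differently around it. In an ADME assay on SW480 cells (Homo sapiens) for cytotoxicity, read by MTT assay, with a stated time of 72 h (a lower number here means a stronger inhibitor, a higher number a weaker inhibitor), compound 1 gives > 100000 nM, and this is a limit of the assay rather than a measured number. Compound 2 gives 96900 nM in this assay. Compound 1 thus stands at the limit itself (the limit of > 100000 nM in this assay, at which 1 of the 2 values shown sits), so where it truly lies is not known, while compound 2 sits close to that same limit.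

Compound 3 `Cc1cccc(NC(=O)c2cccc(/C=C3\CC(=O)N(c4ccccc4)C3=O)c2)c1` has not yet been measured in this assay. It differs from compound 1 by 3-methylphenyl in place of 4-methylphenyl on an amide-type nitrogen, so the same atoms are present and only their arrangement on the methyl-bearing ring changes. Among the measured compounds shown here, no measured pair shows the effect of such a change, so the expectation rests only on the weak values seen so far. The step from compound 1 to compound 3 is expected to be a number no higher from compound 1 to compound 3 (the limit leaves the size open), that is, nothing beyond the usual scatter. Compound 3 is therefore expected to give about 100000 nM in this assay, with an estimated range from 40000 nM to 300000 nM, and a good chance that only a limit is reported once more.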

Compound 3, half-maximal inhibitory concentration: > 100000 nM
Compound 3 ended at the assay's limit; the forecaster's own chance of this, stated with the estimate: 60%; the middle value sits exactly at the limit.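

Compound 1 and compound 3 both end at a limit of this assay rather than at a measured number, so no step can be read between them: the limit of > 100000 nM in this assay, at which 2 of the 3 values shown sit.

The compounds shown leave open where compound 1 and compound 3 truly lie, and whether 3-methylphenyl in place of 4-methylphenyl on an amide-type nitrogen changes the result in this assay at all.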